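Methoxy to hydroxy on the benzyl arm of compound 1

The source may hold more compounds than are shown below. What is called first, only, known or untested is meant among the compounds shown, and "the series" means these compounds.

Going by the values given here, compound 1 `COc1ccc(CNCc2c(OC)cc(Oc3cccc(Nc4ccccc4)c3)cc2OC)cc1` gives 2650 nM in a functional assay on HCT-15 cells (Homo sapiens) for inhibition, read by MTT assay, with a stated time of 72 h (a lower number here means a stronger inhibitor, a higher number a weaker inhibitor), the lower of the two numbers measured so far. Compound 2 `COc1cc(Oc2cccc(Nc3ccccc3)c2)cc(OC)c1CNCCNC(C)=O` gives 5090 nM in this assay; the step of a 1.9-fold higher number from compound 1 to compound 2 (0.28 log units; within the scatter) lies within the scatter. Compound 3 `COc1cc(Oc2cccc(Nc3ccccc3)c2)cc(OC)c1CNCc1ccc(O)cc1` differs from compound 1 by hydrogen in place of methyl on an oxygen on an aromatic ring, that is, 4-methoxybenzyl becomes 4-hydroxybenzyl. Among the compounds with values here, no measured step touches this oxygen; the only step available, a 1.9-fold higher number from compound 1 to compound 2 (0.28 log units; within the scatter), exchanges the whole 4-methoxyphenyl for acetamidomethyl on the saturated chain carbon bound to the amine nitrogen and stays within the scatter, so what sits there has so far made little difference. On that basis no step beyond the scatter is expected in this assay for compound 3 in either direction, and the step is estimated as a 1.1-fold higher number from compound 1 to compound 3 (0.05 log units; within the scatter). Compound 3 is therefore expected to give about 3000 nM in this assay, within a range from 1000 nM to 9000 nM.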

Compound 3, half-maximal inhibitory concentration: 3430 nM
The estimate for compound 3 lay 1.1-fold (0.06 log units) below the measured number, and the stated range covers the measured number.
By their numbers in this assay, from the lowest: compounds 1, 3 and 2 (each within the scatter of the next).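

In this assay, going by these compounds alone, hydrogen in place of methyl on the oxygen of the 4-methoxybenzyl arm gives a 1.3-fold higher number from compound 1 to compound 3 (0.11 log units; within the scatter) and is the one step here confined to this oxygen, so methoxy and hydroxy cannot be told apart at this position. The exchange of acetamidomethyl for 4-hydroxyphenyl on the saturated chain carbon bound to the amine nitrogen gives a 1.5-fold lower number from compound 2 to compound 3 (0.17 log units; within the scatter) and so adds a second group to the 4-methoxyphenyl comparison, again without separating the numbers. No measured evidence bears on the outcome at this oxygen.

On these data alone, with all three compounds within the scatter of one another, it remains open whether any group on this arm can shift the number beyond the scatter. The compounds shown do not tell what a carboxylic acid or an amine in place of the hydroxy of compound 3 would do.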